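Removing the sulfamoylphenylamino group from compound 3

The compounds below may be only part of what the source reports. "The series", "measured", "known", "first", "only" and "open" are said of these compounds alone.

Measured in a functional assay on MCF7 cells (Homo sapiens) for cytotoxicity, with a stated time of 72 h; a higher number here means a weaker inhibitor, a lower number a stronger inhibitor:
- Compound 1 `CCc1cccc(-c2nn3c(c2-c2ccncc2)C(C)C(C)(C)C3)n1`: > 100000 nM, a limit
- Compound 2 `Cc1cccc(-c2nn3c(c2-c2ccnc(Cl)c2)C(C)C(C)(C)C3)n1`: > 100000 nM, a limit
- Compound 3 `CCc1cccc(-c2nn3c(c2-c2ccnc(Nc4ccc(S(N)(=O)=O)cc4)c2)C(C)C(C)(C)C3)n1`: 28000 nM

In this assay, among the compounds with values here, compound 3 gives 28000 nM, the only true number. The other two values sit at the limit of > 100000 nM in this assay, at which 2 of the 3 values shown sit.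

Compound 4 `CCc1cccc(-c2nn3c(c2-c2ccnc(Cl)c2)C(C)C(C)(C)C3)n1` has not yet been measured. It has chloro in place of (4-sulfamoylphenyl)amino on an aromatic carbon.

Within the data shown here, one measured step bears on this change: an at least 3.5-fold lower number from compound 1 to compound 3 (0.55 log units; beyond the scatter), where (4-sulfamoylphenyl)amino replaces hydrogen on an aromatic carbon. Compound 4 loses that same group, although chloro rather than hydrogen takes its place. Compound 2 also carries chloro, and its value of > 100000 nM is a limit.

A higher number is therefore expected in this assay, of a size similar to the measured step, and the result may well be reported only as a limit. The expected change is a 3.6-fold higher number from compound 3 to compound 4 (0.55 log units; beyond the scatter). For compound 4 the estimate is 100000 nM, with an expected range of 50000 nM to 200000 nM.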

Compound 4, half-maximal inhibitory concentration: > 100000 nM
Compound 4 ended at the assay's limit (the forecaster's own chance of this, stated with the estimate: 80%); the middle value sits exactly at the limit.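

In this assay, chloro in place of (4-sulfamoylphenyl)amino on this aromatic carbon gives an at least 3.5-fold higher number from compound 3 to compound 4 (0.55 log units; beyond the scatter). With hydrogen in compound 1 and chloro in compound 4 both at the limit, the small replacements shown at this position do not match (4-sulfamoylphenyl)amino, and compound 3 alone gives a true number. The steps from compound 1 and compound 2 to compound 4 cannot be read, so neither chloro against hydrogen nor methyl against ethyl can be ordered here: the limit of > 100000 nM in this assay, at which 3 of the 4 values shown sit.

Open, on these data alone, is which part of (4-sulfamoylphenyl)amino carries the step; a plain phenylamino group or a simple amine on this carbon would separate the phenyl ring from the sulfamoyl group. Also open, as far as these compounds go, is whether a carboxylic acid in place of the sulfamoyl group would shift the value of compound 3, 28000 nM.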